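Methyl Addition Next to the Amide Nitrogen, Carried to a Second Core

The compounds below may be only part of what the source reports. "The series", "measured", "known", "first", "only" and "open" are said of these compounds alone.

Measured so far:
compound 1 `CC(=O)N(C)C(C)C#CCn1ccnc1` – 3 mg/kg
compound 2 `CC(=O)N(C)CC#CCn1ccnc1` – 1.4 mg/kg
compound 3 `COC(=O)N(C)CC#CCN1CCCC1` – 5.5 mg/kg

These three compounds were examined in a functional assay on the whole organism for agonist activity, with Mus musculus as the target; on this read-out higher numbers stand for an effect only at larger amounts of compound and lower numbers for an effect already at smaller amounts. Compound 2 and compound 1 differ by one change, (methyl in place of hydrogen on a saturated chain carbon bound to an amide-type nitrogen and a triple-bonded carbon), and this gave a 2.1-fold higher number from compound 2 to compound 1 (0.33 log units; beyond the scatter). Compound 3 carries a different core; the difference between the core of compound 3 and that of compound 2 is not broken down here. Compound 3 and compound 1 lie within the scatter of each other in this assay, while compound 3 stands beyond the scatter from compound 2.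

Compound 4 `COC(=O)N(C)C(C)C#CCN1CCCC1` has not yet been measured. It differs from compound 3 by methyl in place of hydrogen on a saturated chain carbon bound to an amide-type nitrogen and a triple-bonded carbon, the same change that turned compound 2 into compound 1. The expectation for compound 4 therefore rests on compound 3 and on the step seen for the same change, a 2.1-fold higher number from compound 2 to compound 1 (0.33 log units; beyond the scatter). Compound 4 is expected to show a 2.0-fold higher number from compound 3 to compound 4 (0.30 log units; within the scatter) in this assay. Compound 4 is estimated at 11 mg/kg, with a range from 5 mg/kg to 25 mg/kg.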

Compound 4, dose for half-maximal effect: 14.2 mg/kg
Compound 4: middle estimate off by 1.3-fold (0.11 log units), on the low side; the measured number falls inside the stated range.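

In this assay methyl in place of hydrogen on a saturated chain carbon bound to an amide-type nitrogen and a triple-bonded carbon gave a 2.6-fold higher number from compound 3 to compound 4 (0.41 log units; beyond the scatter) and this step agrees with the one on the other core: the same change on two cores in this assay, a 2.1-fold higher number (0.33 log units; beyond the scatter) from compound 2 to compound 1 and a 2.6-fold higher number (0.41 log units; beyond the scatter) from compound 3 to compound 4, 1.2-fold (0.08 log units) apart, within the scatter of two such steps. In this series, the change therefore carried from one core to the other with its direction and size preserved. This rests on one matched pair per core, so it does not show that the step would hold on any further core, nor does it explain why the number rises.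

The compounds shown leave open whether ethyl or hydroxymethyl at that carbon would give a similar step. They also leave open whether the step would persist with a longer chain in place of the triple-bonded link.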